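This account rests on a few compounds, and the source may have more. Where it says the series, first, only, none or still open, it means among the compounds named here.

Measured compounds: compound 1 `CC(C)c1onc(-c2c(Cl)cccc2Cl)c1COc1ccc(-c2nc3ccc(C(=O)O)cc3n2C)cc1` gives 7150 nM; compound 2 `CCC(CC)n1c(-c2ccc(OCc3c(-c4c(Cl)cccc4Cl)noc3C(C)C)cc2F)nc2ccc(C(=O)O)cc21` gives > 10000 nM, a limit of the assay; compound 3 `CC(C)c1onc(-c2c(Cl)cccc2Cl)c1COc1ccc(-c2nc3ccc(C(=O)O)cc3n2C)c(Cl)c1` gives 3520 nM.

Among the measured compounds shown here, in an assay on HEK-293T cells for antagonist activity at vitamin D3 receptor (Homo sapiens), read by a luciferase reporter, with a stated time of 24 h (on this read-out higher numbers stand for weaker inhibition and lower numbers for stronger inhibition), compound 3 stands lowest of the two numbers reported, and the single measured step, a 2.0-fold lower number from compound 1 to compound 3 (0.31 log units; beyond the scatter), separates it from compound 1. Compound 4 `CCC(CC)n1c(-c2ccc(OCc3c(-c4c(Cl)cccc4Cl)noc3C(C)C)cc2Cl)nc2ccc(C(=O)O)cc21` differs from compound 3 in one place: pentan-3-yl in place of methyl on an aromatic nitrogen. For the measured compounds named here, no measured step covers this change. Going by the values given here, the only measured compound bearing pentan-3-yl on that nitrogen is compound 2, which sits at the limit of > 10000 nM in this assay, at which 1 of the 3 values shown sits. On that basis the step is expected to run toward a higher number, a 2.3-fold higher number from compound 3 to compound 4 (0.36 log units; beyond the scatter), with a real chance that only a limit is returned. Compound 4 is therefore estimated at 8000 nM, within 2500 nM to 25000 nM.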

Compound 4, half-maximal inhibitory concentration: 1010 nM
Compound 4: middle estimate off by 7.9-fold (0.90 log units), on the high side; measured number below the stated range.
By their numbers in this assay, from the lowest: compound 4; then compound 3; then compound 1. At a limit, above all of these: compound 2.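

In this assay, pentan-3-yl in place of methyl on the aromatic nitrogen lowers the number rather than raising it, with a 3.5-fold lower number from compound 3 to compound 4 (0.54 log units; beyond the scatter). Compound 2 stands at a limit of the assay: the limit of > 10000 nM in this assay, at which 1 of the 4 values shown sits. With pentan-3-yl held on that nitrogen, chloro in place of fluoro on the aromatic carbon gives an at least 9.9-fold lower number from compound 2 to compound 4 (0.99 log units; beyond the scatter), so the limit of compound 2 does not speak against pentan-3-yl itself.

The compounds shown leave open how isopropyl or cyclohexyl would read on that nitrogen. They also leave open how bromo or methoxy would read on that aromatic carbon.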